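Adding Two Chlorines to a Chemokine Receptor Binder

This account rests on a few compounds, and the source may have more. Where it says the series, first, only, none or still open, it means among the compounds named here.

Compound 3 `O=C(NCc1ccc(CNS(=O)(=O)c2ccccc2)cc1)c1ccccc1Cl` carries a 2-chlorophenyl group on a carbonyl carbon. In an assay on MDA-MB-231 cells for binding affinity to C-X-C chemokine receptor type 4 (Homo sapiens), read by immunofluorescence and microscopy, with stated times of 10 min and 30 min (on this read-out higher numbers stand for an effect only at larger amounts of compound and lower numbers for an effect already at smaller amounts), compound 3 gives 10 nM. Compound 1 `Cc1ccc(S(=O)(=O)NCc2ccc(CNC(=O)c3ccncc3)cc2)cc1` gives 10 nM and compound 2 `Cc1ccc(S(=O)(=O)NCc2ccc(CNC(=O)c3ccc(Cl)cc3)cc2)cc1` gives 10 nM, so all three sit level within the scatter. Within the data shown here, the one measured step, no change at the digits printed from compound 1 to compound 2 (within the scatter), shows that exchanging the group on a carbonyl carbon left the read-out flat. Compound 4 `O=C(NCc1ccc(CNS(=O)(=O)c2ccccc2)cc1)c1c(Cl)cc(Cl)cc1Cl` differs from compound 3 by 2,4,6-trichlorophenyl in place of 2-chlorophenyl on a carbonyl carbon. Among the measured compounds shown here, no measured pair adds chlorine atoms in this way, so that flat step is the only guide. The expected step is therefore no change at the digits printed from compound 3 to compound 4 (within the scatter), nothing beyond the scatter. Compound 4 is estimated at 10 nM, with a range from 3 nM to 30 nM.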

Compound 4, effective concentration (reported as EC, without a stated level of effect): 10 nM
Beside the measured number, compound 4's estimate shows no gap at the digits printed; measured number inside the range.
By their numbers in this assay, from the lowest: compounds 1, 2, 3 and 4 (each within the scatter of the next).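

The earlier step swapped one ring for another on the carbonyl carbon, whereas this change keeps the ring and raises its chlorine count, with 9 heavy atoms entering for 7. In this assay this gives no change at the digits printed from compound 3 to compound 4 (within the scatter) and shows that this position takes a ring carrying three chlorines with the read-out still flat. Nothing available gives a reason for this flat result.

Still open, going by these compounds, is whether a ring is needed here at all. A carboxylic acid or a simple amine chain on the carbonyl carbon could show that.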